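A few compounds are considered here, and "the series" means these few. Any claim that something is new, unique, unknown or untested is made for them only; others in the source may bear on it.

Among the compounds with values here, in an assay on mitochondria (strain BALB/c) for inhibition of glycerol-3-phosphate acyltransferase 1, mitochondrial (Mus musculus), read by scintillation counting, with a stated time of 10 min (on this read-out lower numbers stand for stronger inhibition and higher numbers for weaker inhibition), compound 1, `CCCCCCCCS(=O)(=O)Nc1cc(-c2cccc(Cl)c2)ccc1C(=O)O`, gives 13800 nM, the lowest number among the three compounds measured so far. Compound 2, `CCCCCCCCS(=O)(=O)Nc1ccc(-c2ccc(-c3ccccc3)cc2)cc1C(=O)O`, gives 29100 nM in this assay, and compound 3, `CCCCCCCCS(=O)(=O)Nc1ccc(C(=O)c2ccc(CCCC)cc2)cc1C(=O)O`, gives 31700 nM; both of these steps from compound 1 lie beyond the usual scatter, so compound 1 stands as the strongest inhibitor of the three on the numbers available.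

Compound 4, `CCCCCCCCS(=O)(=O)Nc1cc(CCc2ccccc2)ccc1C(=O)O`, has not yet been measured. It differs from compound 1 in one place: phenethyl in place of 3-chlorophenyl on an aromatic carbon. The group that enters is a phenethyl, with one six-membered aromatic ring of carbon only, in place of the 3-chlorophenyl that leaves, on the aromatic carbon that is meta to a large group and para to the carboxy group.

Within the data shown here, no measured pair shows this change directly, so the step from compound 1 to compound 4 can only be expected, not read off. The account expects a modest move toward weaker inhibition, close to or just beyond the scatter, as a 1.6-fold higher number from compound 1 to compound 4 (0.20 log units; within the scatter). Compound 4 is therefore estimated to give 22000 nM in this assay, within a range from 8000 nM to 60000 nM.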

Compound 4, half-maximal inhibitory concentration: 37500 nM
Estimate against measurement, compound 4: 1.7-fold (0.23 log units) below, and the stated range covers the measured number.
By their numbers in this assay, from the lowest: compound 1; then compounds 2, 3 and 4 (each within the scatter of the next).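

Phenethyl in place of 3-chlorophenyl gives a 2.7-fold higher number from compound 1 to compound 4 (0.43 log units; beyond the scatter) in this assay, the first step in this series that changes one place alone. It shows that the aromatic carbon para to a carboxy group is sensitive to this exchange, even though the entering group has the same single six-membered aromatic ring of carbon only as the group that leaves. No measurement available here accounts for this step.

The compounds shown do not separate the loss of the chlorine from the change in how the ring is attached, since both change together in this one step. As far as these compounds go, an unsubstituted phenyl, a benzyl or a 3-chlorophenethyl on this same carbon would be needed to tell these apart, and how an amine or a carboxylic acid on the ring would fare remains open.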